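A second chloro on the core of compound 3

The source may hold more compounds than are shown below. What is called first, only, known or untested is meant among the compounds shown, and "the series" means these compounds.

Three measured compounds share one core and carry the same set of groups, arranged differently. Compound 1 `ClCc1ccc(Cn2cnc3c(Cl)ncnc32)cc1` gives only a limit in a functional assay on OVCAR-4 cells (Homo sapiens) for cytotoxicity, read by sulforhodamine B assay, with a stated time of 48 h (on this read-out lower numbers stand for higher toxicity in this test and higher numbers for lower toxicity in this test), namely > 100000 nM, and therefore no number. That limit is described as the limit of > 100000 nM in this assay, at which 1 of the 3 values shown sits. Compound 2 `ClCc1ccccc1Cn1cnc2c(Cl)ncnc21` gives 45700 nM in this assay, and compound 3 `ClCc1cccc(Cn2cnc3c(Cl)ncnc32)c1` gives 26300 nM. Compound 3 thus holds the lowest of the two numbers, with compound 2 nearest at a gap that lies within the scatter, so no order between the two can be read from these figures.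

Compound 4 `ClCc1cccc(Cn2cnc3c(Cl)nc(Cl)nc32)c1` has not yet been measured. It differs from compound 3 by chloro in place of hydrogen on an aromatic carbon. Among the measured compounds shown here, no measured pair in this set makes the same change, so the size of the step is not known from the data; the account can only say what is expected. A modest move toward stronger cytotoxicity, or none beyond the scatter, is the expected outcome. In this assay compound 4 is expected to give about 15000 nM, with a range from 5000 nM to 50000 nM. The step this estimate implies, a 1.8-fold lower number from compound 3 to compound 4 (0.24 log units; within the scatter), is expected to stay small against the spread of the measured numbers.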

Compound 4, concentration lethal to 50% of the cells: 61700 nM
Estimate against measurement, compound 4: 4.1-fold (0.61 log units) below; measured number above the stated range.
By their numbers in this assay, from the lowest: compounds 3, 2 and 4 (each within the scatter of the next, the first and the last beyond it). At a limit, above all of these: compound 1.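

The carbon between two ring nitrogen atoms turns out not to be a silent position. Among the compounds shown here, compound 1, compound 2 and compound 3 differ only in how the same groups are arranged, so they offered no step on the core itself, whereas in this assay chloro in place of hydrogen at this carbon gives a 2.3-fold higher number from compound 3 to compound 4 (0.37 log units; beyond the scatter), a modest move toward lower toxicity in this test. Nothing in the data shown bears on why the number rises with this change.

As far as these compounds go, whether an amine, a methoxy group or a bromo group on the same carbon would move the number in the same direction, or by a similar size, remains open. From the compounds shown here alone, it is also open whether chloro at this carbon would act in the same way on the arrangement of compound 2, or on that of compound 1, which so far gives only a limit.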